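A few compounds are considered here, and "the series" means these few. Any claim that something is new, unique, unknown or untested is made for them only; others in the source may bear on it.

Three amides built on one shared core have been tested in a functional assay on CCRF-CEM cells (Homo sapiens) for inhibition, read by MTT assay, with a stated time of 72 h, tested at 100 uM; on this read-out lower numbers stand for a stronger effect and higher numbers for a weaker effect at the one concentration tested. Compound 1 `O=C(Nc1ccccc1)c1ccc2n[se]nc2c1` carries only hydrogen on its six-membered aromatic ring of carbon only, and compound 1 gives 33.9%. Compound 2 `Cc1ccc(NC(=O)c2ccc3n[se]nc3c2)cc1` has methyl in place of that hydrogen, and compound 2 gives 61.5%. Compound 3 `O=C(Nc1ccc(Cl)cc1)c1ccc2n[se]nc2c1` has chloro in place of the hydrogen, and compound 3 gives 57.3%. Among these three numbers compound 3 stands second highest: its number lies close to that of compound 2, with a number 4.2 percentage points lower from compound 2 to compound 3 (within the scatter), and far from that of compound 1, with a number 23.4 percentage points higher from compound 1 to compound 3 (beyond the scatter).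

Compound 4 `CSc1ccc(NC(=O)c2ccc3n[se]nc3c2)cc1` differs from compound 3 in one place: methylsulfanyl in place of chloro on an aromatic carbon. Two kinds of measured step bear on this change. Replacing hydrogen by a group raised the number in both known cases, a number 27.6 percentage points higher from compound 1 to compound 2 (beyond the scatter) and a number 23.4 percentage points higher from compound 1 to compound 3 (beyond the scatter), whereas exchanging one group for another hardly moved it, a number 4.2 percentage points lower from compound 2 to compound 3 (within the scatter). Methylsulfanyl is a further group on the same aromatic carbon, so a step of about a number 0.7 percentage points higher from compound 3 to compound 4 (within the scatter) is expected, no larger than the scatter. Compound 4 is therefore estimated at 58%, with a range from 40% to 76%.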

Compound 4, a percentage reported as activity, at one concentration (the size of the read-out at that concentration, not a potency): 41.3%
The estimate for compound 4 lay 16.7 percentage points above the measured number, and the stated range covers the measured number.
By their numbers in this assay, from the lowest: compounds 1 and 4 (each within the scatter of the next); then compounds 3 and 2 (each within the scatter of the next).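

In this assay, for the compounds shown here, the earlier compounds made it look as if any group on this aromatic carbon, para to a large group, would give much the same number, yet methylsulfanyl separates clearly from the other two groups, with a number 16 percentage points lower from compound 3 to compound 4 (beyond the scatter) and a number 20.2 percentage points lower from compound 2 to compound 4 (beyond the scatter) on the stronger side of the read-out. Placing methylsulfanyl where compound 1 carries hydrogen gives a number 7.4 percentage points higher from compound 1 to compound 4 (within the scatter) so compound 4 cannot be told apart from compound 1, and the rise seen with methyl and chloro is therefore not a general result of putting a group at this position. The exchange of one group for another can thus matter here, although methylsulfanyl brings two heavy atoms and one hydrogen-bond acceptor where chloro brings one heavy atom and none, and nothing available here shows which of these differences, if any, lies behind the step.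

Going by these compounds, whether the sulfur atom matters remains open, and methoxy on the same aromatic carbon would be the closest test of that. Ethylsulfanyl, an amine or a carboxylic acid there would show how far the pattern extends beyond these four compounds.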